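Replacing a Thioether Side Group with a Small Amide

The compounds below may be only part of what the source reports. "The series", "measured", "known", "first", "only" and "open" are said of these compounds alone.

Measured so far:
compound 1 `CCN1CCN(C[C@H]2CN(c3ccc(-n4cc(-c5ccccn5)cn4)c(F)c3)C(=O)O2)CC1`: 99 ug/mL
compound 2 `O=C1O[C@@H](CSc2cccs2)CN1c1ccc(-n2cc(-c3ccccn3)cn2)c(F)c1`: > 400 ug/mL

In an ADME assay on HEK293-A cells (Homo sapiens) for cytotoxicity, read by MTT assay, with a stated time of 48 h (on this read-out higher numbers stand for weaker inhibition and lower numbers for stronger inhibition), compound 2 returns only a limit, > 400 ug/mL, and thus stands at the least toxic end of the two values shown (the limit of > 400 ug/mL in this assay, at which 1 of the 2 values shown sits). Among the measured compounds shown here, the only measured step, an at least 4.0-fold higher number from compound 1 to compound 2 (0.60 log units; beyond the scatter), reached that limit. Compound 3 `CNC(=O)[C@H]1CN(c2ccc(-n3cc(-c4ccccn4)cn3)c(F)c2)C(=O)O1` differs from compound 2 by methylcarbamoyl in place of ((thiophen-2-yl)sulfanyl)methyl on a saturated ring carbon. For the measured compounds named here, no measured step covers this change, so the author expects no step beyond the scatter, an at least 1.3-fold lower number from compound 2 to compound 3 (0.12 log units; that floor lies within the scatter), while allowing for some loss toward numbers. Compound 3 is estimated at 300 ug/mL, between 100 ug/mL and 500 ug/mL.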

Compound 3, half-maximal inhibitory concentration: 342 ug/mL
Beside the measured number, compound 3's estimate is 1.1-fold (0.06 log units) below it, within the range that was stated.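

In this assay, putting methylcarbamoyl on this saturated ring carbon, which carries no ring and no sulfur, gives an at least 1.1-fold lower number from compound 2 to compound 3 (0.06 log units; that floor lies within the scatter). The value of compound 2 is a limit and not a number: the limit of > 400 ug/mL in this assay, at which 1 of the 3 values shown sits. The small amide also stands clear of the (4-ethylpiperazin-1-yl)methyl group, with a 3.5-fold higher number from compound 1 to compound 3 (0.54 log units; beyond the scatter), so a thioether is not needed for a number on this side of compound 1. Going by these compounds, how a carboxylic acid or a longer chain on the same ring carbon would read remains open, as does the true distance between compound 2 and compound 3.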